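The compounds below may be only part of what the source reports. "The series", "measured", "known", "first", "only" and "open" are said of these compounds alone.

Compound 1 `C/C=C/COc1cc(/C=C\c2cc(OC)c(OC)c(OC)c2)ccc1OC` gives 161000 nM
Compound 2 `COc1ccc(/C=C\c2cc(OC)c(OC)c(OC)c2)cc1OCc1ccc(Br)cc1` gives 108000 nM

In a functional assay on HT-29 cells (Homo sapiens) for inhibition, read by MTT assay, with a stated time of 3 days (a higher number here means a weaker inhibitor, a lower number a stronger inhibitor), compound 2 at 108000 nM stands within the scatter of compound 1 at 161000 nM. Compound 3 `COc1ccccc1/C=C/CCCOc1cc(/C=C\c2cc(OC)c(OC)c(OC)c2)ccc1OC` has 4-(2-methoxyphenyl)but-3-en-1-yl in place of 4-bromophenyl on a saturated chain carbon bound to an oxygen on an aromatic ring. Among the measured compounds shown here, only one measured step bears on this change, made at the same place: a 1.5-fold lower number from compound 1 to compound 2 (0.17 log units; within the scatter). No step beyond the scatter is therefore expected in this assay, and the estimated step is a 1.1-fold higher number from compound 2 to compound 3 (0.05 log units; within the scatter). Compound 3 is expected at 120000 nM, within an estimated range of 50000 nM to 260000 nM.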

Compound 3, half-maximal inhibitory concentration: 86000 nM
Compound 3: middle estimate off by 1.4-fold (0.14 log units), on the high side; the range from low to high includes it.
By their numbers in this assay, from the lowest: compounds 3, 2 and 1 (each within the scatter of the next).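

In this assay, 4-(2-methoxyphenyl)but-3-en-1-yl in place of 4-bromophenyl gives a 1.3-fold lower number from compound 2 to compound 3 (0.10 log units; within the scatter) and the same group in place of prop-1-en-1-yl gives a 1.9-fold lower number from compound 1 to compound 3 (0.27 log units; within the scatter) at this place on a saturated chain carbon bound to an oxygen on an aromatic ring. The position thus carries groups from prop-1-en-1-yl to this larger group of 12 heavy atoms with all three numbers within the scatter of one another. Nothing available gives a reason for this flat result. From the compounds shown here alone, whether an amine or a carboxylic acid at this place would bring a step beyond the scatter remains open.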